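A few compounds are considered here, and "the series" means these few. Any claim that something is new, unique, unknown or untested is made for them only; others in the source may bear on it.

Working notes on the series. Three compounds of a shared core have numbers in an assay for inhibition of RAC-alpha serine/threonine-protein kinase (Homo sapiens), read by HTRF, with a stated time of 1 h; a higher number here means a weaker inhibitor, a lower number a stronger inhibitor. Compound 1 `Cn1ncc(Cl)c1-c1cc(C(=O)N[C@@H]2CN[C@H](CCn3cncn3)C[C@H]2c2ccc(Cl)c(Cl)c2)oc1Cl` gives 4.47 nM. Compound 2 `Cn1ncc(Cl)c1-c1cc(C(=O)N[C@@H]2CNCC[C@H]2c2ccc(C(F)(F)F)cc2)oc1Cl` gives 9.3 nM. Compound 3 `Cn1ncc(Cl)c1-c1cc(C(=O)N[C@@H]2CN[C@H](CCO)C[C@H]2c2ccc(F)c(F)c2)oc1Cl` gives 0.98 nM. Compound 1 thus holds the second highest of the three numbers: compound 2 sits higher by a margin beyond the scatter, and compound 3 sits lower by a larger margin, also beyond the scatter. Compound 4 `C=CC[C@@H]1C[C@@H](c2ccc(Cl)c(Cl)c2)[C@H](NC(=O)c2cc(-c3c(Cl)cnn3C)c(Cl)o2)CN1` is not yet measured in this assay. It differs from compound 1 in one place: vinyl in place of (1H-1,2,4-triazol-1-yl)methyl on a saturated chain carbon bound to a saturated ring carbon. Going by the values given here, no measured pair shows this change directly, so its effect cannot be read from the data. The step of a 1.8-fold higher number from compound 1 to compound 4 (0.25 log units; within the scatter) is expected to be small, toward a higher number, and likely within the scatter. For compound 4 in this assay the estimate is 8 nM, expected to fall between 3 nM and 25 nM.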

Compound 4, half-maximal inhibitory concentration: 12.4 nM
For compound 4 the middle estimate is 1.6-fold (0.19 log units) below the measured one; the measured number falls inside the stated range.
By their numbers in this assay, from the lowest: compound 3; then compound 1; then compounds 2 and 4 (each within the scatter of the next).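

In this assay, going by these compounds alone, this is the first direct reading at this position: vinyl in place of (1H-1,2,4-triazol-1-yl)methyl on a saturated chain carbon bound to a saturated ring carbon gives a 2.8-fold higher number from compound 1 to compound 4 (0.44 log units; beyond the scatter) as a modest loss. Activity therefore persists with allyl, which has no ring and no hydrogen-bond acceptors, in place of 2-(1H-1,2,4-triazol-1-yl)ethyl. Nothing shown here bears on the origin of this step.

This single pair cannot separate the contributions of the ring, the acceptors and the chain. From the compounds shown here alone, how a terminal primary amine or carboxylic acid on the chain would read remains open.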